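Carboxy Gives Way to Cyano on the Side Chain

A few compounds are considered here, and "the series" means these few. Any claim that something is new, unique, unknown or untested is made for them only; others in the source may bear on it.

Among the measured compounds shown here, only two compounds have been tested so far in a functional assay (trachea) with Cavia porcellus as the target; on this read-out lower numbers stand for an effect already at smaller amounts and higher numbers for an effect only at larger amounts of compound. Compound 1 (`CCCn1c(=O)n(CC(C)=O)c(=O)c2[nH]cnc21`) gives 14900 nM there. Compound 2 (`CCCn1c(=O)n(C)c(=O)c2c1ncn2CCC(=O)O`) returns only a limit of the assay, > 100000 nM, and not a number.

Compound 3 (`CCCn1c(=O)n(C)c(=O)c2c1ncn2CCC#N`) differs from compound 2 in one place: cyano in place of carboxy on a saturated chain carbon, two bonds along the chain from an aromatic nitrogen. This puts cyano in place of carboxy on a saturated chain carbon, two bonds along the chain from an aromatic nitrogen.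

For the measured compounds named here, no measured step of this kind is available, so any change in this assay can only be estimated. Going by the values given here, the sole numerical anchor is compound 1 at 14900 nM. A moderate shift towards lower numbers is expected, although another limit reading remains possible. The expected change is an at least 2.8-fold lower number from compound 2 to compound 3 (0.45 log units; beyond the scatter). For compound 3 the estimated value is 35000 nM, with an expected range of 10000 nM to 100000 nM.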

Compound 3, half-maximal effective concentration: 27600 nM
Compound 3: middle estimate off by 1.3-fold (0.10 log units), on the high side; the measured number falls inside the stated range.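

Changing carboxy to cyano on a saturated chain carbon, two bonds along the chain from an aromatic nitrogen, brings the read-out in this assay into the range where a number can be given (an at least 3.6-fold lower number from compound 2 to compound 3 (0.55 log units; beyond the scatter)). This gives the 2-cyanoethyl chain a numerical anchor, with compound 3 at 27600 nM in this assay, where the 2-carboxyethyl chain had offered none. Compound 2 gives only a limit of the assay, > 100000 nM, so the step fixes a minimum and not a size: the limit of > 100000 nM in this assay, at which 1 of the 3 values shown sits.

On these data alone, how an amine or a primary amide in the same place would read in this assay remains open, as does the effect of a longer chain carrying the cyano group. As far as these compounds go, the true size of the step also stays unknown while one end of it is a limit.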